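One Nitrogen for One Oxygen on the Side Chain

A few compounds are considered here, and "the series" means these few. Any claim that something is new, unique, unknown or untested is made for them only; others in the source may bear on it.

Compound 1, `C#CCNC(=O)C[C@H](NC(=O)c1ccc(C#Cc2ccccc2)cc1)C(=O)NO`: 3
Compound 2, `CC(NC(=O)c1ccc(C#Cc2ccccc2)cc1)C(=O)NO`: > 3
Compound 3, `O=C(N[C@H](CO)C(=O)NO)c1ccc(C#Cc2ccccc2)cc1`: 2

In a physicochemical assay for lipophilicity (a lower number here means a more polar compound, a higher number a more lipophilic compound), compound 3 stands lowest of the two numbers given, with compound 1 the nearest measured neighbour, higher and beyond the scatter. Compound 2 shows only a limit of the assay, (the limit of > 3 in this assay, at which 1 of the 3 values shown sits), not a number.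

Compound 4, `NC[C@H](NC(=O)c1ccc(C#Cc2ccccc2)cc1)C(=O)NO`, has not yet been measured. It differs from compound 3 in one place: a group of 7 heavy atoms (3 carbon, 2 nitrogen, 2 oxygen; no ring) in place of a group of 7 heavy atoms (3 carbon, 1 nitrogen, 3 oxygen; no ring), on an amide-type nitrogen.

For the measured compounds named here, only one measured step speaks to such side-chain changes: a number at least 1.00 log units lower from compound 2 to compound 3 (beyond the scatter). There, exchanging one side chain for another of similar size moved the read-out downward by a clear margin. The step to compound 4 again exchanges side chains of equal size, now trading one oxygen-bearing group for one carrying a second nitrogen. Going by the values given here, no measured pair shows this exact exchange, so the direction is taken by analogy, and a further drop is expected rather than a rise.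

Compound 4 is therefore estimated at 1, between 0 and 2, which is an expected step of a number 1.00 log units lower from compound 3 to compound 4 (beyond the scatter).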

Compound 4, distribution coefficient: 2
Estimate against measurement, compound 4: 1.00 log units below; the range from low to high includes it.
By their numbers in this assay, from the lowest: compounds 3 and 4 (each within the scatter of the next); then compound 1.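

In this assay the exchange of one oxygen for one nitrogen in the side chain gives no change at the digits printed from compound 3 to compound 4 (within the scatter), so at this place, on an amide-type nitrogen, the read-out does not separate these two groups of equal size. The fall seen earlier for compound 3 is shared by compound 4, with a number at least 1.00 log units lower from compound 2 to compound 4 (beyond the scatter) and with a number 1.00 log units lower from compound 1 to compound 4 (beyond the scatter). For compound 2 the read-out is a limit and not a number: the limit of > 3 in this assay, at which 1 of the 4 values shown sits.

The compounds shown leave open whether a side chain ending in a carboxylic acid, or a longer chain carrying the amine, would stay level with compound 4 in this assay or move away from it. They also leave open whether the same exchange of oxygen for nitrogen would give the same result on a different core.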